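Dropping the chloro from compound 1: an expected small step

The compounds below may be only part of what the source reports. "The series", "measured", "known", "first", "only" and "open" are said of these compounds alone.

Measured so far:
compound 1 `O=C(/C=C/c1ccc(/C=C/C(=O)c2ccc(Cl)cc2)o1)NO` — 1350 nM
compound 2 `O=C(NO)c1ccc(/C=C/c2cccc(Cl)c2Cl)o1` — 39300 nM

In a functional assay on PC-3 cells (Homo sapiens) for antiproliferative activity, read by MTT assay, with a stated time of 48 h (on this read-out lower numbers stand for stronger inhibition and higher numbers for weaker inhibition), compound 1 gives 1350 nM, the lowest of the two numbers. In this assay compound 2 gives 39300 nM, a far higher number, and that gap lies beyond the usual scatter of repeat measurements. The two compounds share a furan-linked hydroxamic acid but differ in several places, so no single change can be read from them.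

Compound 3 `O=C(/C=C/c1ccc(/C=C/C(=O)c2ccccc2)o1)NO` has not been measured in this assay. It differs from compound 1 in one place: hydrogen in place of chloro on an aromatic carbon. The chloro leaves and hydrogen enters on an aromatic carbon of a six-membered aromatic ring of carbon only, para to a large group.

Among the compounds with values here, no measured pair shows this change on its own. For compound 3 a small step from compound 1, toward a slightly higher number, is expected, a 1.6-fold higher number from compound 1 to compound 3 (0.21 log units; within the scatter), close to or within the scatter. Compound 3 is therefore estimated at 2200 nM, with a range from 700 nM to 7000 nM.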

Compound 3, half-maximal inhibitory concentration: 13300 nM
Compound 3: middle estimate off by 6.0-fold (0.78 log units), on the low side; measured number outside the range, above it.
By their numbers in this assay, from the lowest: compound 1; then compound 3; then compound 2.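

In this assay the chloro on this aromatic carbon turns out to count for much more than a minor detail: the change from 4-chlorophenyl to phenyl gives a 9.9-fold higher number from compound 1 to compound 3 (0.99 log units; beyond the scatter), a step beyond the usual scatter of repeat measurements. Within the data shown here, compound 1 and compound 3 form the first pair here that differs in one place, so this single change can now be read on its own, which compound 1 and compound 2 could not offer. Nothing measured here gives a reason for the size of this step.

As far as these compounds go, it remains open whether another group on this carbon, such as bromo, methoxy or an amine, would match compound 1 or go beyond it. A single pair also cannot tell whether the same change would give a similar step on a different core.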